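Fluoro in place of bromo: what to expect

The source may hold more compounds than are shown below. What is called first, only, known or untested is meant among the compounds shown, and "the series" means these compounds.

Measured so far in a functional assay on A549 cells (Homo sapiens) for cytotoxicity, read by MTT assay, with a stated time of 48 h; a lower number here means a stronger inhibitor, a higher number a weaker inhibitor
compound 1 (`CC1(C)CCC[C@]2(C)[C@@H](CC[C@@](C)(O)/C=C/c3cncc4ccccc34)[C@](C)(O)CC[C@@H]12`) gives 45700 nM
compound 2 (`CC1(C)CCC[C@]2(C)[C@@H](CC[C@@](C)(O)/C=C/c3ccc(Br)cc3)[C@](C)(O)CC[C@@H]12`) gives 43200 nM

A lower number marks a stronger inhibitor, yet compound 2 stands level with compound 1 because the gap between them is only a 1.1-fold lower number from compound 1 to compound 2 (0.02 log units; within the scatter) and so the two cannot be told apart. Compound 3 (`CC1(C)CCC[C@]2(C)[C@@H](CC[C@@](C)(O)/C=C/c3ccc(F)cc3)[C@](C)(O)CC[C@@H]12`) keeps the core and chain of compound 2, and its difference is fluoro in place of bromo on an aromatic carbon with fluoro in place of bromo on an aromatic carbon, para to a large group. Within the data shown here, no measured step exchanges bromo for fluoro, so the data offer no direct guide. Among the measured compounds shown here, the one step available replaced isoquinolin-4-yl with 4-bromophenyl, a larger exchange of groups, and the number stayed within the scatter. Compound 3 is therefore expected to remain close to compound 2 at 43200 nM with no shift in either direction that could be told from the scatter. In this assay the expected step is a 1.0-fold higher number from compound 2 to compound 3 (0.02 log units; within the scatter) and thus none beyond the scatter. The estimated value for compound 3 is 45000 nM with an expected range of 20000 nM to 90000 nM in repeated measurements.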

Compound 3, half-maximal inhibitory concentration: 3100 nM
Compound 3: the middle estimate sits 15-fold (1.16 log units) above what was measured; the whole stated range lies above it.
By their numbers in this assay, from the lowest: compound 3; then compounds 2 and 1 (each within the scatter of the next).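

Exchanging a single heavy atom on the aromatic carbon, para to a large group, gives a 14-fold lower number from compound 2 to compound 3 (1.14 log units; beyond the scatter) in this assay, so this position can strongly change the result even when the group that leaves and the one that enters are counted as equally small. The earlier compounds shown here gave no hint of this: with 4-bromophenyl in place of isoquinolin-4-yl there was only a 1.1-fold lower number from compound 1 to compound 2 (0.02 log units; within the scatter), while 4-fluorophenyl in that same place gives a 15-fold lower number from compound 1 to compound 3 (1.17 log units; beyond the scatter), which shows that the level numbers of the first two compounds did not mean that this part of the molecule was unimportant. Nothing available here accounts for the large step seen with fluoro.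

As far as these compounds go, it remains open whether a chloro group, a methoxy group or plain hydrogen at this place would stand with fluoro or with bromo, which would show whether fluoro is unusual or bromo is the group holding the number up. Also open, from the compounds shown here alone, is whether fluoro would give a step of this size on a different chain or core, since only the 2-(4-fluorophenyl)ethenyl form appears here.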